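Swapping the benzimidazolyl group of compound 1

The source may hold more compounds than are shown below. What is called first, only, known or untested is meant among the compounds shown, and "the series" means these compounds.

- compound 1 `CCN(CC)CCCn1c(N)c(-c2nc3ccccc3n2C)c2nc(C#N)c(C#N)nc21` gives 7240 nM
- compound 2 `CN(C)CCCCn1c(N)c(-c2nc3ccccc3n2C)c2nc(C#N)c(C#N)nc21` gives 3870 nM

In an ADME assay on HEK293 cells (Homo sapiens) for cytotoxicity, read by MTT assay, with a stated time of 48 h (a higher number here means a weaker inhibitor, a lower number a stronger inhibitor), compound 1 gives 7240 nM and stands level with compound 2 (3870 nM), so neither can be called the stronger inhibitor. Compound 3 `CCN(CC)CCCn1c(N)c(-c2nc3cc(Cl)ccc3[nH]2)c2nc(C#N)c(C#N)nc21` has no number yet. It keeps the 3-(diethylamino)propyl group of compound 1 but exchanges another group (5-chloro-1H-benzimidazol-2-yl in place of 1-methyl-1H-benzimidazol-2-yl on an aromatic carbon). The exchange sits on an aromatic carbon, next to the ring atom that bears an amino group.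

Among the measured compounds shown here, the only measured step (a 1.9-fold lower number from compound 1 to compound 2 (0.27 log units; within the scatter)) lies on the chain rather than at this place, and it stays within the scatter. For the measured compounds named here, no measured compound carries the 5-chloro-1H-benzimidazol-2-yl group, so the data give no direction for this change. No step beyond the scatter is therefore expected (a 1.4-fold lower number from compound 1 to compound 3 (0.16 log units; within the scatter)). In this assay compound 3 is estimated at 5000 nM (range 1500 nM to 15000 nM).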

Compound 3, half-maximal inhibitory concentration: 8420 nM
Beside the measured number, compound 3's estimate is 1.7-fold (0.23 log units) below it; low and high end bracket the measured number.
By their numbers in this assay, from the lowest: compounds 2, 1 and 3 (each within the scatter of the next, the first and the last beyond it).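

In this assay, among the compounds shown here, the exchange of 1-methyl-1H-benzimidazol-2-yl for 5-chloro-1H-benzimidazol-2-yl gives a 1.2-fold higher number from compound 1 to compound 3 (0.07 log units; within the scatter) and so provides the first measured step at this aromatic carbon rather than on the chain. The entering group brings a chlorine and a hydrogen-bond donor and loses the methyl group, yet these differences taken together leave the two compounds within the scatter. Nothing available here offers an explanation for this result.

For the compounds shown here, the single step cannot separate the chlorine from the free ring hydrogen, so a plain 1H-benzimidazol-2-yl or a 5-chloro-1-methyl-1H-benzimidazol-2-yl group would be needed to tell them apart. Also open, from the compounds shown here alone, is how a quite different group at this carbon, such as a phenyl ring or a carboxylic acid, would read in this assay with the same chain in place.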